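Branching the ethyl chain: from compound 3 to compound 4

The compounds below may be only part of what the source reports. "The series", "measured", "known", "first", "only" and "open" are said of these compounds alone.

Measured compounds:
compound 1, `Cc1ccc(OCCCCN(Cc2ccc(C(=O)NO)cc2)c2ncc(-c3ccc(C)cc3)s2)cc1`, 1220 nM
compound 2, `Cc1ccc(-c2cnc(N(Cc3ccc(C(=O)NO)cc3)CC(C)C)s2)cc1`, 9340 nM
compound 3, `CCN(Cc1ccc(C(=O)NO)cc1)c1ncc(-c2ccc(C)cc2)s1`, 10300 nM

In a functional assay on PC-3 cells (Homo sapiens) for antiproliferative activity, read by MTT assay, with a stated time of 48 h (on this read-out lower numbers stand for stronger inhibition of growth and higher numbers for weaker inhibition of growth), compound 3 gives the highest of the three numbers. Its nearest neighbour is compound 2, and the step of a 1.1-fold higher number from compound 2 to compound 3 (0.04 log units; within the scatter) lies within the scatter, so the two cannot be ranked against each other. Its furthest neighbour is compound 1: the step of an 8.4-fold higher number from compound 1 to compound 3 (0.93 log units; beyond the scatter) is beyond the scatter, as is the related step of a 7.7-fold higher number from compound 1 to compound 2 (0.88 log units; beyond the scatter), and both trace back to the loss of the 4-methylphenoxy-bearing chain.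

Compound 4, `Cc1ccc(-c2cnc(N(Cc3ccc(C(=O)NO)cc3)C(C)C)s2)cc1`, differs from compound 3 by methyl in place of hydrogen on a saturated chain carbon bound to a nitrogen on an aromatic ring and a saturated chain carbon; cut one bond further out, the same difference reads ethyl to isopropyl. Among the compounds with values here, the only measured step that bears on this is the one from compound 2 to compound 3, a change of a small saturated substituent on the same nitrogen, and it was within the scatter. A similar small substituent change in compound 4 is therefore expected to bring no step beyond the scatter, in either direction, in this assay.

Compound 4 is accordingly estimated at 10000 nM, with a range from 4000 nM to 25000 nM, which corresponds to an expected step of a 1.0-fold lower number from compound 3 to compound 4 (0.01 log units; within the scatter).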

Compound 4, concentration for 50% growth inhibition: 1150 nM
Estimate against measurement, compound 4: 8.7-fold (0.94 log units) above; measured number below the stated range.
By their numbers in this assay, from the lowest: compounds 4 and 1 (each within the scatter of the next); then compounds 2 and 3 (each within the scatter of the next).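

In this assay, the step of a 9.0-fold lower number from compound 3 to compound 4 (0.95 log units; beyond the scatter) shows that a single methyl in place of hydrogen on this saturated chain carbon, turning ethyl into isopropyl, is enough to move the number beyond the scatter, although the earlier exchange of isobutyl for ethyl on the same nitrogen had not done so. The step of an 8.1-fold lower number from compound 2 to compound 4 (0.91 log units; beyond the scatter) separates isopropyl from isobutyl by a similar margin, while the step of a 1.1-fold lower number from compound 1 to compound 4 (0.03 log units; within the scatter) lies within the scatter, so the small isopropyl cannot be told apart from the 4-(4-methylphenoxy)butyl chain and a long chain is not needed to reach that level. Nothing among the data shown accounts for this sensitivity to one added methyl.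

The compounds shown leave open whether a cyclopropyl or a tert-butyl group on the same nitrogen would keep the number of compound 4 or lose it. They also leave open whether the level shared by compound 1 and compound 4 would hold with an amine or a carboxylic acid at the end of a longer chain.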